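The source may hold more compounds than are shown below. What is called first, only, known or untested is meant among the compounds shown, and "the series" means these compounds.

Two compounds share one core and differ only in the group on a saturated ring carbon. Among the measured compounds shown here, in an assay on CHO cells for displacement of a labelled ligand from 5-hydroxytryptamine receptor 1B (Homo sapiens) (a higher number here means a weaker inhibitor, a lower number a stronger inhibitor), compound 1 `O[C@H]1Cc2ccccc2C1NC1CCN(CCCc2c[nH]c3ccc(-n4cnnc4)cc23)CC1` gives 300 nM, while compound 2 `CC(C)=CCCN(C)C1CCN(CCCc2c[nH]c3ccc(-n4cnnc4)cc23)CC1` gives 24 nM, the lower of the two numbers, and the only measured step is a 13-fold lower number from compound 1 to compound 2 (1.10 log units; beyond the scatter). Compound 3 `c1cc(CNC2CCN(CCCc3c[nH]c4ccc(-n5cnnc5)cc34)CC2)co1` carries the change (((furan-3-yl)methyl)amino in place of methyl(4-methylpent-3-en-1-yl)amino on a saturated ring carbon). That step swapped an amino group bearing a ring for one without, so the reverse direction is expected here, though with a smaller group than in compound 1; the expected step is a 4.2-fold higher number from compound 2 to compound 3 (0.62 log units; beyond the scatter). In this assay compound 3 is estimated at 100 nM, between 35 nM and 300 nM.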

Compound 3, half-maximal inhibitory concentration: 78 nM
For compound 3 the middle estimate is 1.3-fold (0.11 log units) above the measured one; the measured number falls inside the stated range.
By their numbers in this assay, from the lowest: compound 2; then compound 3; then compound 1.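

In this assay, placing ((furan-3-yl)methyl)amino on this saturated ring carbon gives a 3.3-fold higher number from compound 2 to compound 3 (0.51 log units; beyond the scatter), so the ring-free methyl(4-methylpent-3-en-1-yl)amino group keeps the lowest number. Changing the group on the amine nitrogen to (furan-3-yl)methyl from 2-hydroxy-2,3-dihydro-1H-inden-1-yl gives a 3.8-fold lower number from compound 1 to compound 3 (0.59 log units; beyond the scatter), so carrying a ring does not set the number by itself: which ring matters. No evidence here explains either step. Compound 2 and compound 3 also differ in the methyl on that nitrogen, and the compounds shown cannot separate this from the ring. A benzyl group or a 4-methylpent-3-en-1-yl group on an amine bearing a hydrogen would be informative.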